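The source may hold more compounds than are shown below. What is called first, only, known or untested is meant among the compounds shown, and "the series" means these compounds.

Measured compounds in a functional assay with Alpha-1A adrenergic receptor (Homo sapiens) as the target, read by calcium flux; a lower number here means a smaller maximal response, a higher number a larger maximal response:
compound 1 `Cc1nc(-c2ccccc2NCC2=NCCN2)n(C)n1`: 98%
compound 2 `CC(C)n1ncnc1-c1ccccc1NCC1=NCCN1`: 104%
compound 3 `Cn1ncnc1-c1ccccc1NCC1=NCCN1`: 91%

Where compound 3 stands: against compound 2 the step is a number 13 percentage points lower from compound 2 to compound 3 (beyond the scatter), so compound 3 sits apart from compound 2. Against compound 1 the step is a number 7 percentage points lower from compound 1 to compound 3 (within the scatter), so compound 1 and compound 3 cannot be told apart on these numbers. All three values lie close to the reference response.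

Compound 4 `Cn1ccnc1-c1ccccc1NCC1=NCCN1` differs from compound 3 in one place: 1-methyl-1H-imidazol-2-yl in place of 1-methyl-1H-1,2,4-triazol-5-yl on an aromatic carbon. Neither measured step covers a change of this kind. The step from compound 1 to compound 3 swaps a substituent on a ring carbon, the step from compound 2 to compound 3 swaps the substituent on the ring nitrogen; both leave the five-membered ring itself untouched, and both stay close to the scatter. For the measured compounds named here, three changes on the same five-membered ring have thus moved the maximal response only modestly, which is the only guide here.

Expectation: compound 4 is expected near compound 3, with a step of a number 2 percentage points higher from compound 3 to compound 4 (within the scatter) in this assay, not clearly beyond the scatter in either direction. The estimate for compound 4 is 93%, with a range from 80% to 106%.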

Compound 4, largest response reached (reported as maximal response), in percent of the reference or control that the assay uses: 88%
Estimate against measurement, compound 4: 5 percentage points above; measured number inside the range.
By their numbers in this assay, from the lowest: compounds 4, 3, 1 and 2 (each within the scatter of the next, the first and the last beyond it).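

The step of a number 3 percentage points lower from compound 3 to compound 4 (within the scatter) in this assay is the first change shown to the five-membered ring itself rather than to a substituent on it. With 1-methyl-1H-imidazol-2-yl in place of 1-methyl-1H-1,2,4-triazol-5-yl on an aromatic carbon of the six-membered aromatic ring, the ring goes from 3 hetero atoms to 2 and from 3 hydrogen-bond acceptors to 2, yet compound 3 and compound 4 cannot be told apart on maximal response. At this position, then, the triazole ring is not required to keep the response close to the reference, although this rests on a single pair and no explanation of the result is available from the data in hand.

Still open, on these data alone, is whether the response holds when the five-membered ring gives way to a plain phenyl or a pyridine, or when it carries an amine or a carboxylic acid. Also open, as far as these compounds go, is the effect of a longer chain such as n-butyl on the ring nitrogen of the 1-methyl-1H-imidazol-2-yl group, where only methyl appears so far.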